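This account rests on a few compounds, and the source may have more. Where it says the series, first, only, none or still open, it means among the compounds named here.

In an ADME assay on MT4 cells (Homo sapiens) for cytotoxicity, read by MTT assay, with a stated time of 96 h (a lower number here means that less compound is tolerated, a higher number that more compound is tolerated), compound 1 `Cc1ccc(NC(=S)Nc2nc[nH]n2)cc1` gives 59000 nM. Compound 2 `Fc1ccc(NC(=S)Nc2nc[nH]n2)cc1` reaches only the assay limit of > 100000 nM. Compound 3 `S=C(Nc1ccccc1)Nc1nc[nH]n1` likewise stops at the limit, > 100000 nM, so compound 3 stands at the upper edge of the numbers shown, which is the limit of > 100000 nM in this assay, at which 2 of the 3 values shown sit. Compound 4 `S=C(Nc1ccc(Br)cc1)Nc1nc[nH]n1` differs from compound 3 by bromo in place of hydrogen on an aromatic carbon. The measured steps touching compound 3 are an at least 1.6-fold higher number from compound 1 to compound 3 (0.22 log units; that floor lies within the scatter) and a step that the two limits leave unreadable from compound 2 to compound 3; the former sets only a floor that lies within the scatter and the latter has no readable size. No step beyond the scatter is therefore expected for compound 4 in this assay, and another limit is plausible. Compound 4 is estimated at 80000 nM, with a range of 30000 nM to 200000 nM. The expected step is an at least 1.2-fold lower number from compound 3 to compound 4 (0.09 log units; that floor lies within the scatter).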

Compound 4, half-maximal cytotoxic concentration: > 100000 nM
Compound 4: no number, only a limit (the forecaster's own chance of this, stated with the estimate: 55%); middle value at least 1.2-fold (0.09 log units) away from the limit.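

In this assay compound 4 gives > 100000 nM, a limit of the assay and not a number. Going by these compounds alone, the steps from compound 2 and compound 3 to compound 4 cannot be read, and the only readable step is an at least 1.6-fold higher number from compound 1 to compound 4 (0.22 log units; that floor lies within the scatter). Bromo therefore joins fluoro and hydrogen at this position at the limit, with compound 1 the exception: the limit of > 100000 nM in this assay, at which 3 of the 4 values shown sit.

Going by these compounds, only compound 1 has a number, so how far the others lie from it stays open. Also open, on these data alone, is how an amine, a carboxylic acid or a longer chain at this position would read.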